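Methyl for Ethyl Ester: Expected Cytotoxicity of Compound 4

A few compounds are considered here, and "the series" means these few. Any claim that something is new, unique, unknown or untested is made for them only; others in the source may bear on it.

Measured compounds:
Compound 1 `CCC(C)c1cc(/C=C/C(=O)c2ccccc2)cc2cc(C(=O)OC)c(=O)oc12` — 10700 nM
Compound 2 `CCOC(=O)c1cc2cc(/C=C/C(=O)c3ccccc3)cc(C(C)CC)c2oc1=O` — 12900 nM
Compound 3 `CCOC(=O)c1cc2cc(/C=C/C(=O)c3ccc(Cl)cc3)cc(C(C)CC)c2oc1=O` — 12900 nM

In a functional assay on A549 cells (Homo sapiens) for cytotoxicity, read by sulforhodamine B assay, with a stated time of 48 h (a lower number here means a stronger inhibitor, a higher number a weaker inhibitor), compound 2 gives 12900 nM. Compound 1 differs from it by hydrogen in place of methyl on a saturated chain carbon bound to an oxygen next to a carbonyl group, and the step is a 1.2-fold lower number from compound 2 to compound 1 (0.08 log units; within the scatter). Compound 3 differs from compound 2 by chloro in place of hydrogen on an aromatic carbon, with a step of no change at the digits printed from compound 2 to compound 3 (within the scatter), so compound 3 stands level with compound 2 at the digits reported.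

Compound 4 `CCC(C)c1cc(/C=C/C(=O)c2ccc(Cl)cc2)cc2cc(C(=O)OC)c(=O)oc12` has not been measured. It differs from compound 3 by hydrogen in place of methyl on a saturated chain carbon bound to an oxygen next to a carbonyl group, the same change made from compound 2 to compound 1, at a place described in the same words. The two cores differ by chloro in place of hydrogen on an aromatic carbon. Because a 1.2-fold lower number from compound 2 to compound 1 (0.08 log units; within the scatter) lay within the scatter, the expected step from compound 3 to compound 4 is a 1.2-fold lower number from compound 3 to compound 4 (0.07 log units; within the scatter), resting on that single earlier step and on compound 3 giving 12900 nM. The estimate for compound 4 in this assay is 11000 nM, expected to fall between 6000 nM and 20000 nM.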

Compound 4, half-maximal inhibitory concentration: 16700 nM
Estimate against measurement, compound 4: 1.5-fold (0.18 log units) below; low and high end bracket the measured number.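

In this assay, the change from ethoxycarbonyl to methoxycarbonyl on the core carrying chloro gives a 1.3-fold higher number from compound 3 to compound 4 (0.11 log units; within the scatter), and set beside the same change on the core without chloro, it shows no difference beyond the scatter: the same change on two cores in this assay, a 1.2-fold lower number (0.08 log units; within the scatter) from compound 2 to compound 1 and a 1.3-fold higher number (0.11 log units; within the scatter) from compound 3 to compound 4, 1.6-fold (0.19 log units) apart, within the scatter of two such steps

The chloro change, read on the methyl esters, gives a 1.6-fold higher number from compound 1 to compound 4 (0.19 log units; within the scatter), and it likewise agrees with its earlier reading on the ethyl esters: the same change on two cores in this assay, no change at the digits printed (within the scatter) from compound 2 to compound 3 and a 1.6-fold higher number (0.19 log units; within the scatter) from compound 1 to compound 4, 1.6-fold (0.19 log units) apart, within the scatter of two such steps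

For the compounds shown here, each change therefore carries between these two cores without a detectable difference, but all four steps lie within the scatter, so this shows only that neither change moved the number measurably here, not that a step of any real size would transfer or that the same would hold on other cores.

From the compounds shown here alone, whether a carboxylic acid or a longer chain such as propoxycarbonyl in place of these esters would give a step beyond the scatter stays open. The same is true of an amine or a methoxy group in place of chloro.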